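The source may report more compounds than this note shows. Statements on the series, on what has been measured and on what is new or still open speak of the compounds shown alone.

Compound 1 `SC1=NC(n2nc(-c3ccccc3)nc2-c2ccccc2)=CC(c2ccccc2Cl)N1` and compound 2 `O=[N+]([O-])c1cccc(C2C=C(n3cc(-c4ccccc4)nc3-c3ccccc3)N=C(S)N2)c1` share a common core but differ from each other in more than one place. In a functional assay on the whole organism with Mus musculus as the target, in the maximal electroshock model, with a stated time of 4 h (a lower number here means that less compound is needed, a higher number that more compound is needed for the effect), compound 1 gives 300 mg/kg. In this assay compound 2 gives 300 mg/kg, level with compound 1 at the digits recorded, so the two stand together within the scatter of the method and no order between them can be claimed. Compound 3 `COc1ccc(C2C=C(n3cc(-c4ccccc4)nc3-c3ccccc3)N=C(S)N2)cc1` has not yet been measured. It differs from compound 2 in one place: 4-methoxyphenyl in place of 3-nitrophenyl on a saturated ring carbon. Among the compounds with values here, no pair of measured compounds separated by a single change is available, and the two measured compounds, which carry different groups at that saturated ring carbon, gave the same reading. The change is therefore expected to bring no shift beyond the scatter, and the step of no change at the digits printed from compound 2 to compound 3 (within the scatter) is the estimate. Compound 3 is expected to give about 300 mg/kg in this assay, with a range from 100 mg/kg to 600 mg/kg.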

Compound 3, minimum effective dose: 300 mg/kg
Beside the measured number, compound 3's estimate shows no gap at the digits printed; low and high end bracket the measured number.
By their numbers in this assay, from the lowest: compounds 1, 2 and 3 (each within the scatter of the next).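

Within the data shown here, the reading in this assay shows no change at the digits printed from compound 2 to compound 3 (within the scatter) when 4-methoxyphenyl takes the place of 3-nitrophenyl on a saturated ring carbon, the first step here that isolates a single change. Compound 1 and compound 2 differ in more than one place, so their level readings could not be tied to this position, whereas here the rest of the molecule stays fixed and the exchange of these two substituted phenyl groups leaves the minimum effective dose within the scatter. Nothing at hand bears on why the reading stays level.

On these data alone, it remains open whether the reading would hold with an amine, a carboxylic acid or a longer alkyl chain at this saturated ring carbon. As far as these compounds go, it is also open whether any group at this position could lower the dose needed.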